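Lengthening the methyl of compound 3 to propyl

The source may hold more compounds than are shown below. What is called first, only, known or untested is meant among the compounds shown, and "the series" means these compounds.

Measured in a functional assay on A549 cells (Homo sapiens) for antiproliferative activity, read by CCK-8 assay, with a stated time of 72 h; on this read-out higher numbers stand for weaker inhibition and lower numbers for stronger inhibition:
- Compound 1 `Nc1ccccc1NC(=O)c1ccc(COc2ccc([N+](=O)[O-])cc2)cc1`: > 32000 nM, a limit of the assay
- Compound 2 `Nc1ccccc1NC(=O)c1ccc(COc2ccccc2)cc1`: 6760 nM
- Compound 3 `Cc1ccc(OCc2ccc(C(=O)Nc3ccccc3N)cc2)cc1`: 5430 nM

Compound 3, at 5430 nM, cannot be separated from compound 2: a 1.2-fold lower number from compound 2 to compound 3 (0.10 log units; within the scatter) lies within the scatter. Compound 4 `CCCc1ccc(OCc2ccc(C(=O)Nc3ccccc3N)cc2)cc1` differs from it by ethyl in place of hydrogen on a saturated chain carbon bound to an aromatic carbon, so methyl becomes propyl. Among the compounds with values here, the closest precedent is the change from hydrogen to methyl, a 1.2-fold lower number from compound 2 to compound 3 (0.10 log units; within the scatter), which made no clear difference. The larger steps, an at least 4.7-fold lower number from compound 1 to compound 2 (0.67 log units; beyond the scatter) and an at least 5.8-fold lower number from compound 1 to compound 3 (0.77 log units; beyond the scatter), replace nitro and rest on (the limit of > 32000 nM in this assay, at which 1 of the 3 values shown sits), so they bear only weakly on this change. No step beyond the scatter is therefore expected, and the expected step is a 1.2-fold lower number from compound 3 to compound 4 (0.08 log units; within the scatter). For compound 4 the estimated value in this assay is 4500 nM, with an expected range of 1800 nM to 12000 nM.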

Compound 4, half-maximal inhibitory concentration: 5210 nM
Compound 4: the middle estimate sits 1.2-fold (0.06 log units) below what was measured; low and high end bracket the measured number.
By their numbers in this assay, from the lowest: compounds 4, 3 and 2 (each within the scatter of the next). At a limit, above all of these: compound 1.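

Within this assay, extending methyl to propyl at this position leaves no readable difference: a 1.0-fold lower number from compound 3 to compound 4 (0.02 log units; within the scatter). Even the full replacement of hydrogen by propyl stays unresolved, at a 1.3-fold lower number from compound 2 to compound 4 (0.11 log units; within the scatter), so these three small carbon-only substituents cannot be told apart here. Propyl in place of nitro gives an at least 6.1-fold lower number from compound 1 to compound 4 (0.78 log units; beyond the scatter), but that step rests on compound 1, whose value is a limit: the limit of > 32000 nM in this assay, at which 1 of the 4 values shown sits.

On these data alone, whether a chain longer than propyl, an amine or a carboxylic acid at this position would give a step beyond the scatter remains open.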